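The source may hold more compounds than are shown below. What is called first, only, known or untested is meant among the compounds shown, and "the series" means these compounds.

Measured compounds and their numbers in an ADME assay for permeability, using PAMPA, at pH 7.4; a higher number here means that the compound crosses the layer faster, a lower number that the compound crosses the layer more slowly:

compound 1, `Cc1ccc(NC(=O)Nc2cc(C)nc3ccccc23)cc1` — compound 1 gives 669 10^-6 cm/s
compound 2, `Cc1cc(NC(=O)Nc2ccc(N)cc2)c2ccccc2n1` — compound 2 gives 530 10^-6 cm/s
compound 3, `Cc1cc(NC(=O)Nc2ccccc2F)c2ccccc2n1` — compound 3 gives 817 10^-6 cm/s

All three share one core and differ only in the aryl group on the amide-type nitrogen or in a substituent on it. Compound 3 gives the numerically highest of the three numbers, but a 1.2-fold higher number from compound 1 to compound 3 (0.09 log units; within the scatter) and a 1.5-fold higher number from compound 2 to compound 3 (0.19 log units; within the scatter) are both within the scatter, as is a 1.3-fold lower number from compound 1 to compound 2 (0.10 log units; within the scatter), so the three compounds are not separated in this assay.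

Compound 4, `Cc1cc(NC(=O)Nc2cccc(Cl)c2)c2ccccc2n1`, is not yet measured. It differs from compound 3 as follows: 3-chlorophenyl in place of 2-fluorophenyl on an amide-type nitrogen

The measured steps that bear on this change are those that alter the same aryl group on the same nitrogen: a 1.2-fold higher number from compound 1 to compound 3 (0.09 log units; within the scatter) and a 1.5-fold higher number from compound 2 to compound 3 (0.19 log units; within the scatter). Both swap one substituted phenyl for another at this position and both remain within the scatter. Among the compounds with values here, with no step exceeding the scatter, the expectation for a further change of substituent on this phenyl is no step beyond the scatter; the step expected from compound 3 to compound 4 is a 1.1-fold lower number from compound 3 to compound 4 (0.04 log units; within the scatter). Compound 4 is therefore estimated at 750 10^-6 cm/s, with a range from 450 10^-6 cm/s to 1200 10^-6 cm/s.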

Compound 4, apparent permeability: 566 10^-6 cm/s
Compound 4: middle estimate off by 1.3-fold (0.12 log units), on the high side, and the stated range covers the measured number.
By their numbers in this assay, from the lowest: compounds 2, 4, 1 and 3 (each within the scatter of the next).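

In this assay, the change on the amide-type nitrogen from 2-fluorophenyl to 3-chlorophenyl gives a 1.4-fold lower number from compound 3 to compound 4 (0.16 log units; within the scatter); this is the first step shown between two halogen-bearing phenyl groups, and the two groups match in heavy-atom count and in their zero counts of hydrogen-bond donors and acceptors. Set against the other aryl groups at this position, 3-chlorophenyl gives a 1.1-fold higher number from compound 2 to compound 4 (0.03 log units; within the scatter) and a 1.2-fold lower number from compound 1 to compound 4 (0.07 log units; within the scatter), so with four aryl groups now in hand, all six steps among compounds 1 to 4 stay within the scatter, including those to compound 2, whose 4-aminophenyl carries an amino group. Nothing shown offers an explanation for the size of any of these steps.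

All four compounds keep a substituted phenyl on this nitrogen and the same shared core, so the set leaves open whether a carboxylic acid on the phenyl, or a saturated ring or longer alkyl chain in place of it, would give a step beyond the scatter. Going by these compounds, whether the same substituent moved to another place on the phenyl would matter also stays open, as no substituent appears here in more than one place.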